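The compounds below may be only part of what the source reports. "The series", "measured", "known", "first", "only" and "open" are said of these compounds alone.

In an ADME assay on HOS cells (Homo sapiens) for cytotoxicity, read by luminescence and ATP content, with a stated time of 48 h (on this read-out higher numbers stand for lower toxicity in this test and lower numbers for higher toxicity in this test), compound 1 `Nc1c(C(=O)NCc2ccc(F)cc2F)c(=O)n(O)c2ncc(CCCCCCOCc3ccccc3)cc12` gives 14400 nM and compound 2 `Nc1c(C(=O)NCc2ccc(F)cc2F)c(=O)n(O)c2ncc(CCc3ccccc3)cc12` gives 18000 nM. The two sit within the scatter of each other, as a 1.3-fold higher number from compound 1 to compound 2 (0.10 log units; within the scatter) shows. Compound 3 `Nc1c(C(=O)NCc2ccc(F)cc2F)c(=O)n(O)c2ncc(CCCOCCO)cc12` stands apart, reported as > 250000 nM, which is a limit of the assay and not a number. This is the only limit among the three values, as the limit of > 250000 nM in this assay, at which 1 of the 3 values shown sits, records.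

Compound 4 `Nc1c(C(=O)NCc2ccc(F)cc2F)c(=O)n(O)c2ncc(CCC(=O)O)cc12` keeps the shared core and changes only the end of the chain: carboxy in place of (2-hydroxyethoxy)methyl on a saturated chain carbon, two bonds along the chain from an aromatic carbon.

Two large measured steps lead to compound 3, an at least 17-fold higher number from compound 1 to compound 3 (1.23 log units; beyond the scatter) and an at least 13-fold higher number from compound 2 to compound 3 (1.14 log units; beyond the scatter). Each replaces a group ending in a phenyl ring with one that has no ring. Compound 4 has no such ring either, so it resembles compound 3 on the one feature that separates the measured compounds. Among the compounds with values here, no measured step exchanges one ringless chain end for another, so this comparison is only indirect. In this assay, no change beyond the scatter is expected, and another limit is quite likely.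

The estimated step is an at least 1.1-fold lower number from compound 3 to compound 4 (0.05 log units; that floor lies within the scatter).

For compound 4 the estimated value is 220000 nM, with an expected range of 100000 nM to 300000 nM.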

Compound 4, half-maximal cytotoxic concentration: > 250000 nM
Compound 4: a limit, no number (the forecaster's own chance of this, stated with the estimate: 70%); middle value at least 1.1-fold (0.05 log units) away from the limit.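

In this assay, compound 4 gives > 250000 nM, which is a limit of the assay and not a number, so a second ringless chain end, this time carboxy, now stands at that limit alongside the earlier one: the limit of > 250000 nM in this assay, at which 2 of the 4 values shown sit.

Both steps from the compounds whose chains end in a phenyl ring are large, an at least 13-fold higher number from compound 2 to compound 4 (1.14 log units; beyond the scatter) and an at least 17-fold higher number from compound 1 to compound 4 (1.23 log units; beyond the scatter), so in all four compounds the ring-ended chains give the low numbers and the ringless chains the limit, with none going against this. With both values being limits, the step between compound 3 and compound 4 cannot be read, and the exchange of (2-hydroxyethoxy)methyl for carboxy therefore shows no order between these two groups.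

From the compounds shown here alone, how far the true values of compound 3 and compound 4 lie beyond the limit remains open, so any difference between them could still be hidden there. Going by these compounds, it is also open whether the absence of a ring alone goes with the limit, a question that a plain hexyl chain or a chain ending in an amine would put to the test at this position.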